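Ring Expansion on the Aromatic Nitrogen of Compound 1

The source may hold more compounds than are shown below. What is called first, only, known or untested is meant among the compounds shown, and "the series" means these compounds.

The account starts from compound 1 `CN1CCC(n2cc(S(=O)(=O)c3cccc4ccccc34)c3ccccc32)C1`, which was tested in a functional assay on HeLa cells for antagonist activity at 5-hydroxytryptamine receptor 6 (Homo sapiens), read by cAMP accumulation and immunoassay, with a stated time of 10 min; on this read-out higher numbers stand for larger maximal responses and lower numbers for smaller maximal responses; in this assay compound 1 gives 98%. Its companion, compound 2 `CN1CCC(n2cc(S(=O)(=O)c3cccc4cccnc34)c3ccccc32)C1`, was measured under the same conditions, and in this assay compound 2 gives 97%. Compound 1 holds the higher of the two numbers, but compound 2 sits so close that the gap lies within the usual scatter, so no order between them can be claimed.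

The next compound, compound 3 `CN1CCCC(n2cc(S(=O)(=O)c3cccc4ccccc34)c3ccccc32)C1`, differs from compound 1 in one place: 1-methylpiperidin-3-yl in place of 1-methylpyrrolidin-3-yl on an aromatic nitrogen. Among the measured compounds shown here, no measured pair shows the effect of this change, so the step is an expectation only. Since both measured compounds reach close to the full maximal response, the author expects the step from compound 1 to compound 3 to be a number 3 percentage points lower from compound 1 to compound 3 (within the scatter), nothing beyond the scatter. Compound 3 is therefore estimated to give 95%, within a range from 82% to 103%.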

Compound 3, largest response reached (reported as Imax), in percent of the reference or control that the assay uses: 87%
For compound 3 the middle estimate is 8 percentage points above the measured one; measured number inside the range.
By their numbers in this assay, from the lowest: compounds 3, 2 and 1 (each within the scatter of the next, the first and the last beyond it).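

Compound 1 and compound 2 share the same 1-methylpyrrolidin-3-yl group, so neither could show whether the group on the aromatic nitrogen matters. With 1-methylpiperidin-3-yl in its place, this assay gives a number 11 percentage points lower from compound 1 to compound 3 (beyond the scatter), a modest step but the first one here that lies beyond the scatter, so this position is not indifferent to a change from a five-membered to a six-membered non-aromatic ring. Nothing at hand explains this step.

On these data alone, it remains open whether the same exchange would have a similar effect on the core of compound 2. It is also unknown how a 1-methylazetidin-3-yl ring or an open chain such as 2-(dimethylamino)ethyl on the same aromatic nitrogen would compare with compound 1.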